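The source may report more compounds than this note shows. Statements on the series, on what has been measured and on what is new or still open speak of the compounds shown alone.

Measured in a functional assay on the whole organism for activation, with Mus musculus as the target; on this read-out lower numbers stand for an effect already at smaller amounts and higher numbers for an effect only at larger amounts of compound:
- Compound 1 `CCOC1(c2cc(F)cc(OCc3ccc(-n4ccnc4C)cc3)c2)CCOCC1`: 5 mg/kg
- Compound 2 `Cc1nccn1-c1ccc(COc2cc(F)cc(C3(C(=O)N(C)C)CCOCC3)c2)cc1`: > 20 mg/kg (a limit of the assay, not a number)
- Compound 3 `CCOC(=O)C1(c2cc(F)cc(OCc3ccc(-n4ccnc4C)cc3)c2)CCOCC1`: 16 mg/kg

Compound 3 holds the higher of the two exact numbers, and compound 1 is its nearest neighbour. Compound 4 `CSC1(c2cc(F)cc(OCc3ccc(-n4ccnc4C)cc3)c2)CCOCC1` carries methylsulfanyl in place of ethoxycarbonyl on a saturated ring carbon. Within the data shown here, two measured steps bear on this: a 3.2-fold higher number from compound 1 to compound 3 (0.51 log units; beyond the scatter) and an at least 4.0-fold higher number from compound 1 to compound 2 (0.60 log units; beyond the scatter). Both put a carbonyl-bearing group where compound 1 has ethoxy, and both raise the number; neither of the other compounds goes against this. Going by these compounds, the entering group has no carbonyl, so a return toward compound 1 at 5 mg/kg is expected, although methylsulfanyl itself is untested. In this assay the expected change is a 2.7-fold lower number from compound 3 to compound 4 (0.43 log units; beyond the scatter), a modest step to a lower number. For compound 4 the estimate is 6 mg/kg, with an expected range from 2.5 mg/kg to 15 mg/kg.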

Compound 4, dose for half-maximal effect: 5 mg/kg
For compound 4 the middle estimate is 1.2-fold (0.08 log units) above the measured one, and the stated range covers the measured number.
By their numbers in this assay, from the lowest: compounds 1 and 4 (each within the scatter of the next); then compound 3. At a limit, above all of these: compound 2.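

At this saturated ring carbon in this assay, methylsulfanyl matches ethoxy (no change at the digits printed from compound 1 to compound 4 (within the scatter)), so the earlier low number is not unique to ethoxy. Methylsulfanyl also gives lower numbers than both carbonyl-bearing groups (a 3.2-fold lower number from compound 3 to compound 4 (0.51 log units; beyond the scatter); an at least 4.0-fold lower number from compound 2 to compound 4 (0.60 log units; beyond the scatter)), and none of the four compounds goes against this split. The step from compound 2 rests on a limit of the assay, not a number: the limit of > 20 mg/kg in this assay, at which 1 of the 4 values shown sits.

Going by these compounds, whether a longer sulfur-bearing chain keeps the number of compound 4 remains open. So does the outcome for an amine or a carboxylic acid at this carbon.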